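Cyclohexyl in place of methoxy on the compound 1 core

This account rests on a few compounds, and the source may have more. Where it says the series, first, only, none or still open, it means among the compounds named here.

Compound 1 `COc1ccc2ncc(-c3nn[nH]n3)cc2c1` gives 10 mg/kg in a functional assay on the whole organism (strain Sprague-Dawley) for inhibition, with Rattus norvegicus as the target (a higher number here means that more compound is needed for the effect, a lower number that less compound is needed), the lower of the two numbers in hand, with compound 2 `O=C(O)c1cnc2c(Cl)cccc2c1` standing at 25 mg/kg, a gap beyond the usual scatter. Compound 3 `CCc1cccc2cc(C(=O)O)cnc12` reaches only the limit of the assay, > 50 mg/kg, and no number. Going by the values given here, the one step measured in one place, an at least 2.0-fold higher number from compound 2 to compound 3 (0.30 log units; that floor lies within the scatter), is a small substituent giving way to a short alkyl chain on the same aromatic carbon; its floor rests on the limit (the limit of > 50 mg/kg in this assay, at which 1 of the 3 values shown sits).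

Compound 4 `c1nc2ccc(C3CCCCC3)cc2cc1-c1nn[nH]n1` differs from compound 1 by cyclohexyl in place of methoxy on an aromatic carbon. Among the compounds with values here, no measured step covers this exact exchange; the nearest is the alkyl-for-halogen step from compound 2 to compound 3, which moved the number up. An upward step is therefore expected for compound 4, of the order of a 3.0-fold higher number from compound 1 to compound 4 (0.48 log units; beyond the scatter), with a real chance that the assay returns only its limit. The estimate for compound 4 is 30 mg/kg, within the range 10 mg/kg to 100 mg/kg.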

Compound 4, minimum effective dose: 5 mg/kg
The estimate for compound 4 lay 6.0-fold (0.78 log units) above the measured number; the whole stated range lies above it.
By their numbers in this assay, from the lowest: compounds 4 and 1 (each within the scatter of the next); then compound 2. At a limit, above all of these: compound 3.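

In this assay, cyclohexyl in place of methoxy on this aromatic carbon gives a 2.0-fold lower number from compound 1 to compound 4 (0.30 log units; within the scatter), so the two compounds cannot be told apart, even though the entering group brings a six-membered non-aromatic ring and no hydrogen-bond acceptor. This position therefore carries either group without a step beyond the scatter, which the earlier step, an at least 2.0-fold higher number from compound 2 to compound 3 (0.30 log units; that floor lies within the scatter), could not show, since it belongs to a different pair of compounds and rests on a limit. Nothing in hand gives a reason for this tolerance.

Going by these compounds, whether an amine, a phenyl ring or a longer alkyl chain on the same aromatic carbon would keep the number in this range stays open. Also open, on these data alone, is whether cyclohexyl would be accepted in the same way on the core of compound 2.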